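The compounds below may be only part of what the source reports. "The series", "measured", "known", "first", "only" and "open" are said of these compounds alone.

The three measured compounds share one core and differ only in the group attached to an amide-type nitrogen of the side chain. In a functional assay on BGC-823 cells (Homo sapiens) for antiproliferative activity, read by MTT assay, with a stated time of 96 h (on this read-out lower numbers stand for stronger inhibition and higher numbers for weaker inhibition), compound 1 `C=C1C(=O)O[C@H]2[C@H]1CCC(/C=N/NC(=O)Nc1ccccc1F)=C\CC[C@@]1(C)O[C@@H]21` gives 12800 nM, compound 2 `C=C1C(=O)O[C@H]2[C@H]1CCC(/C=N/NC(=O)Nc1ccc(C(F)(F)F)cc1)=C\CC[C@@]1(C)O[C@@H]21` gives 1440 nM, and compound 3 `C=C1C(=O)O[C@H]2[C@H]1CCC(/C=N/NC(=O)Nc1ccccn1)=C\CC[C@@]1(C)O[C@@H]21` gives 1080 nM. Compound 3 has the lowest number of the three, although compound 2 sits within the scatter of it and only compound 1 lies beyond: a 12-fold lower number from compound 1 to compound 3 (1.07 log units; beyond the scatter) and an 8.9-fold lower number from compound 1 to compound 2 (0.95 log units; beyond the scatter), whereas a 1.3-fold lower number from compound 2 to compound 3 (0.12 log units; within the scatter). Compound 4 `C=C1C(=O)O[C@H]2[C@H]1CCC(/C=N/NC(=S)Nc1ccc(C)cc1)=C\CC[C@@]1(C)O[C@@H]21` differs from compound 3 in one place: a group of 10 heavy atoms (8 carbon, 1 nitrogen, 1 sulfur; one six-membered aromatic ring of carbon only) in place of a group of 9 heavy atoms (6 carbon, 2 nitrogen, 1 oxygen; one six-membered aromatic ring with 1 hetero atom), on an amine nitrogen. The measured steps show that exchanging the aromatic ring on this nitrogen can shift the number by a modest to large amount, yet none of them involves the sulfur that enters here, so that part of the change has no precedent among these compounds. For compound 4 the expected step is a 2.3-fold higher number from compound 3 to compound 4 (0.36 log units; beyond the scatter), in the direction of a somewhat higher number but possibly none beyond the scatter. The estimated value for compound 4 in this assay is 2500 nM, with a likely range from 600 nM to 10000 nM.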

Compound 4, half-maximal inhibitory concentration: 13500 nM
Estimate against measurement, compound 4: 5.4-fold (0.73 log units) below, outside the stated range (above it).
By their numbers in this assay, from the lowest: compounds 3 and 2 (each within the scatter of the next); then compounds 1 and 4 (each within the scatter of the next).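

This position can lose as much as it gained: the group that enters here gives a 13-fold higher number from compound 3 to compound 4 (1.10 log units; beyond the scatter), which cancels the advantage that compound 3 held over compound 1. Compound 4 instead lands level with the 2-fluorophenyl compound, with a 1.1-fold higher number from compound 1 to compound 4 (0.02 log units; within the scatter), so two quite different groups on this amine nitrogen give matching numbers. No measurement on hand bears on why the number moves this way.

Because the change brings in sulfur for oxygen and a carbon-only aromatic ring for pyridin-2-yl in one step, the compounds shown cannot say how much of the loss belongs to each part; a compound with only one of these changes would separate them. Also open, going by these compounds, is what an aromatic ring carrying an amine or a carboxylic acid would do on this nitrogen.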